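The source may report more compounds than this note shows. Statements on the series, on what has been measured and on what is new or still open speak of the compounds shown alone.

Measured compounds:
Compound 1 `C/C(=C\CC/C(C)=C/CC[C@@H]1[C@@]2(C)CCC(=O)C(C)(C)[C@H]2CC[C@@]1(C)O)CC/C=C(\C)C(=O)OCc1cn(-c2ccccc2)nn1`: in a functional assay on MDA-MB-231 cells (Homo sapiens) for antiproliferative activity, read by MTT assay, with a stated time of 48 h (on this read-out lower numbers stand for stronger inhibition and higher numbers for weaker inhibition), compound 1 reaches only the assay limit > 150000 nM.
Compound 2 `C/C(=C\CC/C(C)=C/CC[C@@H]1[C@@]2(C)CCC(=O)C(C)(C)[C@H]2CC[C@@]1(C)O)CC/C=C(\C)C(=O)OCc1cn(-c2cccc(C(F)(F)F)c2)nn1`: in this assay compound 2 reaches only the assay limit > 150000 nM.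
Compound 3 `C/C(=C\CC/C(C)=C/CC[C@@H]1[C@@]2(C)CCC(=O)C(C)(C)[C@H]2CC[C@@]1(C)O)CC/C=C(\C)C(=O)OCc1cn(-c2ccccc2F)nn1`: in this assay compound 3 reaches only the assay limit > 150000 nM.

Compound 3 therefore stands where every value shown stands, at the limit (the limit of > 150000 nM in this assay, at which 3 of the 3 values shown sit). Compound 4 `COc1ccccc1-n1cc(COC(=O)/C(C)=C/CC/C(C)=C/CC/C(C)=C/CC[C@@H]2[C@@]3(C)CCC(=O)C(C)(C)[C@H]3CC[C@@]2(C)O)nn1` differs from compound 3 by methoxy in place of fluoro on an aromatic carbon. Within the data shown here, the steps that change the same ring, a step that the two limits leave unreadable from compound 1 to compound 3 and a step that the two limits leave unreadable from compound 2 to compound 3, give no readable size, and a step that the two limits leave unreadable from compound 1 to compound 2 likewise, so no measured step offers a number to build on. Because all three values sit at the limit (the limit of > 150000 nM in this assay, at which 3 of the 3 values shown sit), the step expected from this change, a step that the limit leaves unreadable from compound 3 to compound 4, is most likely no readable change. Compound 4 is estimated at 200000 nM, with a range from 100000 nM to 500000 nM, and will most probably again give only a limit.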

Compound 4, half-maximal inhibitory concentration: > 150000 nM
Compound 4: only a limit was reported (the forecaster's own chance of this, stated with the estimate: 85%); the middle value lies beyond the limit too.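

Among these compounds, no step among compound 1, compound 2, compound 3 and compound 4 can be read, because all four give only a limit: the limit of > 150000 nM in this assay, at which 4 of the 4 values shown sit. Going by these compounds, whether any change on this aromatic ring alters activity in this assay stays open.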